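The source may report more compounds than this note shows. Statements on the series, on what has been measured and on what is new or still open speak of the compounds shown alone.

Compound 3, with the structure `COc1cc2nc(N3CCN(C(=O)C(C)(C)C)[C@H]4CCCC[C@H]43)nc(N)c2cc1OC`, gives 6.17 nM in an assay on CHO cells for displacement of a labelled ligand from Alpha-1D adrenergic receptor (Homo sapiens), with a stated time of 30 min (a lower number here means a stronger inhibitor, a higher number a weaker inhibitor), and so sits at the high end of the three numbers: compound 2, of structure `CCCCCC(=O)N1CCN(c2nc(N)c3cc(OC)c(OC)cc3n2)[C@@H]2CCCC[C@@H]21`, gives 3.72 nM, and compound 1, of structure `COc1cc2nc(N3CCN(C(C)=O)[C@@H]4CCCC[C@@H]43)nc(N)c2cc1OC`, gives 0.151 nM, the latter well beyond the scatter from compound 3. The step to compound 4, whose structure is `COc1cc2nc(N3CCN(C(C)=O)[C@H]4CCCC[C@H]43)nc(N)c2cc1OC`, is methyl in place of tert-butyl on a carbonyl carbon.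

Going by the values given here, only one measured step changes the group on this carbonyl carbon: a 1.7-fold higher number from compound 2 to compound 3 (0.22 log units; within the scatter). That exchange of one alkyl group for another left the inhibition constant essentially where it was. Among the compounds with values here, no measured step trims the group on the carbonyl carbon down to a single carbon while the rest of compound 3 is held fixed; compound 1 carries an acetyl group and gives a far lower number, but its structure differs from compound 4 elsewhere, and no step connects the two directly.

On that basis the expectation for compound 4 is a moderately lower number, a 2.5-fold lower number from compound 3 to compound 4 (0.39 log units; beyond the scatter), with wide uncertainty because the single shown step, a 1.7-fold higher number from compound 2 to compound 3 (0.22 log units; within the scatter), was within the scatter. The estimate for compound 4 in this assay is 2.5 nM, within a range from 0.4 nM to 15 nM.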

Compound 4, inhibition constant: 105 nM
For compound 4 the middle estimate is 42-fold (1.62 log units) below the measured one, outside the stated range (above it).
By their numbers in this assay, from the lowest: compound 1; then compounds 2 and 3 (each within the scatter of the next); then compound 4.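

In this assay, the group on the carbonyl carbon proves to matter once it is cut back to methyl, which the earlier exchange of pentyl for tert-butyl, a 1.7-fold higher number from compound 2 to compound 3 (0.22 log units; within the scatter), gave no sign of: removing the tert-butyl group gives a 17-fold higher number from compound 3 to compound 4 (1.23 log units; beyond the scatter). The pentyl compound gives a step of the same direction, a 28-fold higher number from compound 2 to compound 4 (1.45 log units; beyond the scatter), so among compounds 2, 3 and 4 the acetyl compound stands alone at the high end, while the two larger acyl groups stay within the scatter of each other. The acetyl group does not by itself fix the number, however, as the widest gap in the set, a 700-fold higher number from compound 1 to compound 4 (2.84 log units; beyond the scatter), goes with a change that leaves that group untouched, and it can be traced to one difference alone: the fact that compounds 1 and 4 differ only in the configuration as drawn.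

The compounds shown leave open whether pentyl and tert-butyl would give similar numbers in the configuration of compound 1, where the acetyl group gives so low a number. They also leave open where an ethyl or propyl group on the carbonyl carbon would fall between the methyl of compound 4 and the larger groups of compound 2 and compound 3.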